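Cyclopropyl in place of isopropyl on an aromatic nitrogen

The source may report more compounds than this note shows. Statements on the series, on what has been measured and on what is new or still open speak of the compounds shown alone.

In a functional assay on KG-1 cells (Homo sapiens) for antiproliferative activity, read by CCK-8 assay, with a stated time of 72 h (on this read-out lower numbers stand for stronger inhibition and higher numbers for weaker inhibition), compound 1 (`Cc1ccc(C(=O)Nc2cccc(C(F)(F)F)c2)cc1-c1ccc2c(-c3cn[nH]c3)n[nH]c2c1`) gives > 1000 nM as a limit of the assay and not a number. Among the compounds with values here, compound 2 (`Cc1ccc(C(=O)Nc2cccc(C(F)(F)F)c2)cc1-c1ccc2c(-c3cnn(C(C)C)c3)n[nH]c2c1`) gives 452 nM in this assay and so holds the only true number of the pair. Within the data shown here, the one measured step is an at least 2.2-fold lower number from compound 1 to compound 2 (0.34 log units; beyond the scatter) and it bears on the next change only in part: it puts a group on the same aromatic nitrogen, whereas the next change exchanges one group for another. Compound 3 (`Cc1ccc(C(=O)Nc2cccc(C(F)(F)F)c2)cc1-c1ccc2c(-c3cnn(C4CC4)c3)n[nH]c2c1`) carries cyclopropyl in place of isopropyl on an aromatic nitrogen, the difference being cyclopropyl in place of isopropyl on an aromatic nitrogen and nothing else in the structure differs. Among the measured compounds shown here, with compound 2 at 452 nM as the starting point and no measured step that compares two groups there, no change beyond the scatter is expected in this assay in either direction. The expected step is a 1.1-fold higher number from compound 2 to compound 3 (0.04 log units; within the scatter) and it would stay within the scatter. For compound 3 the estimate is 500 nM with an expected range from 180 nM to 1300 nM in this assay.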

Compound 3, half-maximal inhibitory concentration: 108 nM
Compound 3: the middle estimate sits 4.6-fold (0.67 log units) above what was measured; the measured number lies below the stated range.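

Within the data shown here, the earlier step showed only that a group on this aromatic nitrogen goes with a lower number than hydrogen; the new comparison shows that the choice of group also counts. In this assay, exchanging isopropyl for cyclopropyl, with 3 heavy atoms leaving and 3 entering and no hydrogen-bond donor or acceptor on either side, gives a 4.2-fold lower number from compound 2 to compound 3 (0.62 log units; beyond the scatter), so the position separates two groups of equal heavy-atom count, one open and one a three-membered ring. Set against hydrogen, cyclopropyl gives an at least 9.2-fold lower number from compound 1 to compound 3 (0.96 log units; beyond the scatter), but this size is only a bound, because compound 1 stands at a limit of the assay and not at a number: the limit of > 1000 nM in this assay, at which 1 of the 3 values shown sits.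

The compounds shown leave open whether methyl, cyclobutyl or a longer chain ending in an amine on this nitrogen would give a number nearer that of the cyclopropyl or the isopropyl compound. They also cannot tell why cyclopropyl gives the lower number, or whether this step would hold on cells other than the one line shown here.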